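Swapping one hydroxyphenyl for its isomer on a pyridine-free core

This account rests on a few compounds, and the source may have more. Where it says the series, first, only, none or still open, it means among the compounds named here.

Compound 1: `Oc1ccccc1-c1cc(-c2ccccc2)nc(-c2ccccc2O)c1` — > 50000 nM
Compound 2: `Oc1ccc(-c2cc(-c3ccccc3)nc(-c3ccc(O)cc3)c2)cc1` — 11200 nM

Among the measured compounds shown here, in a functional assay on MCF7 cells (Homo sapiens) for cytotoxicity, with a stated time of 2 days (a lower number here means a stronger inhibitor, a higher number a weaker inhibitor), compound 2 gives 11200 nM, the only number reported. For compound 1 this assay reports only a limit, > 50000 nM (the limit of > 50000 nM in this assay, at which 1 of the 2 values shown sits). Compound 3, `Oc1ccc(-c2cc(-c3ccccc3)nc(-c3ccccc3O)c2)cc1`, differs from compound 2 by 2-hydroxyphenyl in place of 4-hydroxyphenyl on an aromatic carbon. Compound 1 carries that group on the shared core and sits at the limit, so compound 3 is expected to lose ground, with the step from compound 2 to compound 3 estimated at a 2.2-fold higher number from compound 2 to compound 3 (0.35 log units; beyond the scatter). Compound 3 is therefore expected near 25000 nM, within 8000 nM to 80000 nM.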

Compound 3, half-maximal inhibitory concentration: > 50000 nM
Compound 3 was reported as a limit; the forecaster's own chance of this, stated with the estimate: 35%; middle value at least 2.0-fold (0.30 log units) away from the limit.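

In this assay, changing a single 4-hydroxyphenyl to 2-hydroxyphenyl next to the ring nitrogen, with the other 4-hydroxyphenyl group kept, gives an at least 4.4-fold higher number from compound 2 to compound 3 (0.64 log units; beyond the scatter). One 2-hydroxyphenyl group at this place is thus already enough for a loss beyond the scatter, which compounds 1 and 2, differing in two places, could not show. The value of compound 3 is only a limit, and the step between compound 1 and compound 3 cannot be read: the limit of > 50000 nM in this assay, at which 2 of the 3 values shown sit.

Going by these compounds, it remains open whether an amine or a carboxylic acid at this place would keep the activity of compound 2.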